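Pyrazole-linked benzoxazinones: effect of the aryl substituent

This account rests on a few compounds, and the source may have more. Where it says the series, first, only, none or still open, it means among the compounds named here.

Measured compounds:
compound 1 `COc1ccc(-c2nc(-c3ccccc3)c(-c3ccc4c(c3)NC(=O)CO4)[nH]2)cc1`: 38.1%
compound 2 `COc1ccc(-n2cc(-c3ccccc3)c(-c3ccc4c(c3)NC(=O)CO4)n2)cc1`: 42.6%
compound 3 `Cc1ccccc1-n1cc(-c2ccccc2)c(-c2ccc3c(c2)NC(=O)CO3)n1`: 85.3%

In a functional assay on A549 cells (Homo sapiens) for cytotoxicity, read by colorimetric assay and MTT assay, with a stated time of 3 days, tested at 20 uM (on this read-out lower numbers stand for a stronger effect and higher numbers for a weaker effect at the one concentration tested), compound 3 gives the highest of the three numbers, which on this read-out means the weakest effect; its nearest neighbour is compound 2, and compound 1 lies furthest away. Among the compounds with values here, the single one-place step among the measured compounds is a number 42.7 percentage points higher from compound 2 to compound 3 (beyond the scatter), a large rise beyond the scatter. Compound 4 `O=C1COc2ccc(-c3nn(-c4ccc(Br)cc4)cc3-c3ccccc3)cc2N1` is obtained from compound 3 by the change (4-bromophenyl in place of 2-methylphenyl on an aromatic nitrogen). Within the data shown here, the one measured step bears on this change only indirectly: it shows that exchanging the aryl group on the aromatic nitrogen can move the number by a large amount, and that a 4-substituted phenyl gave the lower number. Among the measured compounds shown here, compound 4 is therefore expected to fall back toward the number of compound 2, though bromine and methoxy are different groups and no step between them has been measured. The expected step is a number 30.3 percentage points lower from compound 3 to compound 4 (beyond the scatter). The estimated value for compound 4 is 55%, within a range from 30% to 85%.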

Compound 4, a percentage reported as activity, at one concentration (the size of the read-out at that concentration, not a potency): 58.8%
Beside the measured number, compound 4's estimate is 3.8 percentage points below it, within the range that was stated.
By their numbers in this assay, from the lowest: compounds 1 and 2 (each within the scatter of the next); then compound 4; then compound 3.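

In this assay the change to 4-bromophenyl gives a number 26.5 percentage points lower from compound 3 to compound 4 (beyond the scatter) on this aromatic nitrogen, so a second 4-substituted phenyl group also reads lower than the 2-methylphenyl group of compound 3. The substituent on that phenyl group matters as well: bromo in place of methoxy gives a number 16.2 percentage points higher from compound 2 to compound 4 (beyond the scatter) and shows that these two 4-substituted phenyl groups are not interchangeable at this position. Nothing available explains either step.

Going by these compounds, it remains open whether the higher number of compound 3 belongs to the methyl group itself or to where it sits on the phenyl ring, a question that 4-methylphenyl on the same nitrogen would address. Also open, on these data alone, is how an amine or a carboxylic acid on that phenyl group would read in this assay.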